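The source may report more compounds than this note shows. Statements on the series, on what has been measured and on what is new or still open speak of the compounds shown alone.

Compound 1 `C/C=C(\C)C(=O)O[C@@H]1[C@]2(OC(=O)C3CC3)C=C3C4=CC(=O)O[C@@H](c5ccoc5)[C@]4(C)CC[C@@H]3[C@@]3(C)[C@H](C[C@]1(C)[C@H]3[C@@H](O)C(=O)OC)O2` and compound 2 `C/C=C(\C)C(=O)O[C@@H]1[C@]2(OC(=O)CC)C=C3C4=CC(=O)O[C@@H](c5ccoc5)[C@]4(C)CC[C@@H]3[C@@]3(C)[C@H](C[C@]1(C)[C@H]3[C@@H](O)C(=O)OC)O2` were both tested in a functional assay on SK-OV-3 cells (Homo sapiens) for inhibition, read by MTT assay, with a stated time of 24 h; on this read-out higher numbers stand for weaker inhibition and lower numbers for stronger inhibition. Compound 1 gives > 100000 nM, which is a limit of the assay and not a number. Compound 2 gives > 100000 nM, which is likewise a limit and not a number. Compound 2 thus stands at the limit of > 100000 nM in this assay, at which 2 of the 2 values shown sit. For the measured compounds named here, the only measured step, a step that the two limits leave unreadable from compound 1 to compound 2, has no readable size, so it offers no measure for the next change. Compound 3 `C/C=C(\C)C(=O)O[C@@H]1[C@]2(OC(=O)CC)C=C3C4=CC(=O)O[C@@H](c5ccoc5)[C@]4(C)CC[C@@H]3[C@@]3(C)[C@H](C[C@]1(C)[C@H]3[C@@H](OC(=O)CC)C(=O)OC)O2` differs from compound 2 in one place: propanoyl in place of hydrogen on an oxygen on a saturated carbon. This is propanoyl in place of hydrogen on an oxygen on a saturated carbon, or hydroxy to propanoyloxy. Going by the values given here, no measured step covers this kind of change, so the data fix neither the size nor the direction of any shift in this assay. The expectation rests on compound 2, whose entry of > 100000 nM is a limit. The expected outcome is no clear move away from that limit, with the estimated step being a number no higher from compound 2 to compound 3 (the limit leaves the size open). Compound 3 is estimated at 100000 nM, with an expected range from 30000 nM to 200000 nM.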

Compound 3, half-maximal inhibitory concentration: > 100000 nM
Compound 3: a limit, no number; the forecaster's own chance of this, stated with the estimate: 75%; the middle value lies on the limit itself.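

In this assay compound 3 gives > 100000 nM, which is a limit of the assay and not a number. Compound 2 and compound 3 both carry limits, so no step can be read between them. The compounds shown leave open whether any of these changes shifts inhibition at all, with all of them standing at one place: the limit of > 100000 nM in this assay, at which 3 of the 3 values shown sit.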